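Pyridin-2-yl for 2-methoxyphenyl: cytotoxicity working notes

The compounds below may be only part of what the source reports. "The series", "measured", "known", "first", "only" and "open" are said of these compounds alone.

In an ADME assay on HEK293 cells (Homo sapiens) for cytotoxicity, with a stated time of 6 h (on this read-out lower numbers stand for higher toxicity in this test and higher numbers for lower toxicity in this test), compound 1 `CCCCNc1nc(N)nc2cccc(OCc3ccccc3)c12` gives 10000 nM as a measured value.

Compound 2 `CCCCNc1nc(N)nc2cccc(OCc3ccccc3OC)c12` reads > 25000 nM in this assay and this is a limit of the assay, not a number. Its place in the series is therefore given only by the limit of > 25000 nM in this assay, at which 1 of the 2 values shown sits, and not by an exact value.

Next is compound 3 `CCCCNc1nc(N)nc2cccc(OCc3ccccn3)c12`, and the change from compound 2 is pyridin-2-yl in place of 2-methoxyphenyl on a saturated chain carbon bound to an oxygen on an aromatic ring.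

Within the data shown here, the one measured step that bears on this is an at least 2.5-fold higher number from compound 1 to compound 2 (0.39 log units; beyond the scatter), for methoxy in place of hydrogen on an aromatic carbon. Compound 3 has no methoxy, so in this assay a modest move to a lower number is expected, back toward compound 1 at 10000 nM. A reading at the limit remains possible.

The estimated step is an at least 1.4-fold lower number from compound 2 to compound 3 (0.16 log units; that floor lies within the scatter), reckoned from a limit and so uncertain.

For compound 3 the estimate is 17000 nM, with an expected range of 7000 nM to 35000 nM.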

Compound 3, half-maximal cytotoxic concentration: > 25000 nM
Compound 3: only a limit was reported; the forecaster's own chance of this, stated with the estimate: 35%; at least 1.4-fold (0.16 log units) between middle value and limit.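

In this assay, pyridin-2-yl in place of phenyl on a saturated chain carbon bound to an oxygen on an aromatic ring gives an at least 2.5-fold higher number from compound 1 to compound 3 (0.39 log units; beyond the scatter), so at this place the move to a higher number, and with it to lower toxicity in this test, is no longer seen with the methoxy of compound 2 alone and also occurs with a ring that carries no methoxy. Compound 2 and compound 3 both read at a limit of the assay, so the step between them cannot be read, and neither pyridin-2-yl nor 2-methoxyphenyl can be ranked over the other. Two different replacements of the phenyl of compound 1 now end at the same edge of the read-out: the limit of > 25000 nM in this assay, at which 2 of the 3 values shown sit.

On these data alone, how far compound 2 and compound 3 lie past that limit stays open, and with it the relative size of the two changes. Also open, as far as these compounds go, is whether the higher number holds for a group of another kind at this place, such as an amine or a carboxylic acid on the saturated chain carbon bound to an oxygen on an aromatic ring.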